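The compounds below may be only part of what the source reports. "The series", "measured", "known", "first", "only" and "open" are said of these compounds alone.

Among the measured compounds shown here, compound 2 `CCc1ccccc1N(CC(=O)NCc1ccc(Br)cc1)S(=O)(=O)c1ccc(C)cc1` gives 22.9 nM in a functional assay on CHO-K1 cells for antagonist activity at prostaglandin E2 receptor EP1 subtype (Homo sapiens), read by FLIPR and calcium flux (on this read-out lower numbers stand for stronger inhibition and higher numbers for weaker inhibition), the lowest of the two numbers so far; the nearest is compound 1 `CCc1ccccc1N(CC(=O)NCc1ccccc1)S(=O)(=O)c1ccc(C)cc1`, which in this assay gives 224 nM. For the measured compounds named here, the only step measured, a 9.8-fold lower number from compound 1 to compound 2 (0.99 log units; beyond the scatter), came from bromo in place of hydrogen on an aromatic carbon. Compound 3 `CCc1ccccc1N(CC(=O)NCc1ccccc1OC)S(=O)(=O)c1ccc(C)cc1` differs from compound 2 by 2-methoxyphenyl in place of 4-bromophenyl on a saturated chain carbon bound to an amide-type nitrogen. Going by the values given here, no measured step bears directly on this change: the bromo that carried the gain in a 9.8-fold lower number from compound 1 to compound 2 (0.99 log units; beyond the scatter) is removed, and a methoxy enters at a different place on the ring, for which no comparison exists. The loss of the bromine suggests a number nearer to compound 1 than to compound 2, so compound 3 is expected to move by a 6.6-fold higher number from compound 2 to compound 3 (0.82 log units; beyond the scatter) toward weaker inhibition, with wide uncertainty. Compound 3 is therefore estimated at 150 nM, within the range 40 nM to 600 nM.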

Compound 3, inhibition constant: 1070 nM
Compound 3: middle estimate off by 7.1-fold (0.85 log units), on the low side, outside the stated range (above it).
By their numbers in this assay, from the lowest: compound 2; then compound 1; then compound 3.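

In this assay, among the compounds shown here, the 2-methoxyphenyl group does not simply return the number to that of the unsubstituted ring: a 4.8-fold higher number from compound 1 to compound 3 (0.68 log units; beyond the scatter), so the methoxy group is the first ring substituent here to go with weaker inhibition. A substituent on this ring can therefore move the number in either direction, and the full exchange, a 47-fold higher number from compound 2 to compound 3 (1.67 log units; beyond the scatter), goes well past the level of compound 1, which has neither bromo nor methoxy. No measurement on these compounds offers a reason for the opposite directions of bromo and methoxy.

Neither substituent appears at the other's place on the ring, so the effects of the group and of its place cannot be separated. As far as these compounds go, whether a chloro or a methyl group on that ring would go with the bromo or with the methoxy also stays open.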